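This account rests on a few compounds, and the source may have more. Where it says the series, first, only, none or still open, it means among the compounds named here.

Of the compounds shown here, three built on one shared core have been measured in an assay on isolated protein for inhibition of Rho-associated protein kinase 2 (Homo sapiens); on this read-out lower numbers stand for stronger inhibition and higher numbers for weaker inhibition. Compound 1 `COc1cccc(CNC(=O)c2cn(C)c3nc(-c4cn[nH]c4)ccc23)c1` gives < 1 nM, which is a limit of this assay rather than a number (the limit of < 1 nM in this assay, at which 1 of the 3 values shown sits). Compound 3 `COc1cccc(CN(C)C(=O)c2c[nH]c3cc(-c4cn[nH]c4)ccc23)c1` gives 2 nM. Compound 2 `COc1cccc(CN(C(=O)c2c[nH]c3nc(-c4cn[nH]c4)ccc23)C2CC2)c1`, which carries a cyclopropyl on its amide-type nitrogen, gives 6 nM; of the two numbers shown, this is the higher one, and its gap to compound 3 lies beyond the usual scatter of repeated measurements.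

Compound 4 `COc1cccc(CN(CCCN2CCN(C)CC2)C(=O)c2c[nH]c3nc(-c4cn[nH]c4)ccc23)c1` has not yet been measured in this assay. It differs from compound 2 in one place: 3-(4-methylpiperazin-1-yl)propyl in place of cyclopropyl on an amide-type nitrogen. Among the compounds with values here, no measured pair among the three compounds shows a change of this kind, so there is no direct guide to its effect. The expected step of a 1.3-fold higher number from compound 2 to compound 4 (0.12 log units; within the scatter) is therefore a small one, within the usual scatter, with no clear direction. Compound 4 is estimated at 8 nM in this assay, with a likely range from 2 nM to 40 nM.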

Compound 4, half-maximal inhibitory concentration: 62 nM
The estimate for compound 4 lay 7.8-fold (0.89 log units) below the measured number; measured number outside the range, above it.
By their numbers in this assay, from the lowest: compound 3; then compound 2; then compound 4. At a limit, below all of these: compound 1.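

The earlier compounds shown here showed only that a cyclopropyl on this amide-type nitrogen is compatible with strong inhibition; they did not show how much the group there can matter. In this assay, placing 3-(4-methylpiperazin-1-yl)propyl there in place of cyclopropyl gives a 10-fold higher number from compound 2 to compound 4 (1.01 log units; beyond the scatter), so the choice of group on this nitrogen clearly changes the read-out, and this long chain ending in a ring weakens inhibition. Nothing given here explains why this step is so large.

A single step cannot separate the contribution of the propyl chain from that of the methylpiperazine ring. A plain propyl chain, or a propyl chain ending in morpholine or in a dimethylamino group, on this nitrogen would leave open how far each part accounts for the loss.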